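Swapping chloro for methyl on the aryl ring of compound 3

The compounds below may be only part of what the source reports. "The series", "measured", "known", "first", "only" and "open" are said of these compounds alone.

Of the compounds shown here, three have been measured in a functional assay on NIH3T3 cells for agonist activity at Urotensin-2 receptor (Homo sapiens), with a stated time of 5 days; on this read-out lower numbers stand for smaller maximal responses and higher numbers for larger maximal responses. Compound 1 `Cc1ccc(C(CCN(C)C)NC(=O)CCc2ccccc2)cc1` gives 73%, compound 2 `Cc1ccc(C(CCN(C)C)NC(=O)CCc2ccc(C(F)(F)F)cc2)cc1` gives 60%, and compound 3 `COc1ccc(CCC(=O)NC(CCN(C)C)c2ccc(Cl)cc2)cc1` gives 101%, the highest of the three numbers. Among the measured compounds shown here, the only measured step, a number 13 percentage points lower from compound 1 to compound 2 (beyond the scatter), changes a different ring and a different group, so it bears only loosely on the next change. Compound 4 `COc1ccc(CCC(=O)NC(CCN(C)C)c2ccc(C)cc2)cc1` differs from compound 3 by methyl in place of chloro on an aromatic carbon. Compound 1, which carries the same 4-methylphenyl, shows a lower number than compound 3, so a downward step is expected, a number 14 percentage points lower from compound 3 to compound 4 (beyond the scatter). Compound 4 is therefore estimated at 87%, within a range from 66% to 105%.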

Compound 4, largest response reached (reported as efficacy), in percent of the reference or control that the assay uses: 67%
Beside the measured number, compound 4's estimate is 20 percentage points above it; the range from low to high includes it.
By their numbers in this assay, from the lowest: compounds 2, 4 and 1 (each within the scatter of the next, the first and the last beyond it); then compound 3.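

In this assay the para position of this ring proves sensitive, with methyl in place of chloro giving a number 34 percentage points lower from compound 3 to compound 4 (beyond the scatter) and nothing else altered. With the 4-methylphenyl kept, methoxy on the other ring gives a number 7 percentage points higher from compound 2 to compound 4 (within the scatter) against trifluoromethyl and a number 6 percentage points lower from compound 1 to compound 4 (within the scatter) against hydrogen, so here methoxy stands apart from neither group, although compounds 1 and 2 do differ beyond the scatter. No measurement at hand explains the drop from chloro to methyl. As far as these compounds go, whether bromo or an amine at this place would match chloro stays open. So does whether chloro would raise the response with hydrogen or trifluoromethyl on the other ring.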